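The source may hold more compounds than are shown below. What is called first, only, known or untested is meant among the compounds shown, and "the series" means these compounds.

In a functional assay on cells (Homo sapiens) for cytotoxicity, read by propidium iodide staining, with a stated time of 4 days (on this read-out higher numbers stand for weaker inhibition and lower numbers for stronger inhibition), compound 2 `CNC1=CC(=O)c2cc(C)ncc2C1=O` gives 4160 nM, the lowest of the two numbers recorded. Compound 1 `CNC1=CC(=O)c2c(cnc(C)c2C)C1=O` gives 18700 nM in this assay, and the step of a 4.5-fold lower number from compound 1 to compound 2 (0.65 log units; beyond the scatter) separates them. Compound 3 `Cc1cc2c(cn1)C(=O)C(NCl)=CC2=O` differs from compound 2 by chloro in place of methyl on an amine nitrogen. Among the measured compounds shown here, the single measured step concerns a methyl on an aromatic carbon, not a substituent on the amine nitrogen, so no measured step bears on this change. The expected step is therefore a 1.0-fold higher number from compound 2 to compound 3 (0.00 log units; within the scatter), not beyond the scatter. Compound 3 is estimated at 4200 nM, with a range from 1200 nM to 15000 nM.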

Compound 3, half-maximal inhibitory concentration: 1570 nM
For compound 3 the middle estimate is 2.7-fold (0.43 log units) above the measured one, and the stated range covers the measured number.
By their numbers in this assay, from the lowest: compound 3; then compound 2; then compound 1.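

In this assay, among the compounds shown here, chloro in place of methyl on the amine nitrogen gives a 2.6-fold lower number from compound 2 to compound 3 (0.42 log units; beyond the scatter), so this position, which no earlier step had touched, also responds to a single change. Together with the methyl on an aromatic carbon, the amine nitrogen is now a second place where one change moves the number beyond the scatter. Nothing available explains this shift.

From the compounds shown here alone, how a bromo, an ethyl or a longer chain on the amine nitrogen would read stays open. Going by these compounds, it is also open whether chloro would give a similar step on the core of compound 1.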